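The source may report more compounds than this note shows. Statements on the series, on what has been measured and on what is new or still open speak of the compounds shown alone.

Working notes on the series. The shared core is shown by compound 1 `C=C1C[C@]23C[C@@]1(O)CC[C@H]2c1ccc(OS(=O)(=O)c2ccc(C)cc2)c(C)c1[C@@H]3Cn1cc(-c2ccc(Br)cc2)nn1` and compound 2 `C=C1C[C@]23C[C@@]1(O)CC[C@H]2c1ccc(OS(=O)(=O)c2ccc(C)cc2)c(C)c1[C@@H]3Cn1cc(-c2ccc(OC)cc2)nn1`, both carrying a ((4-methylphenyl)sulfonyl)oxy group on the core and differing only in the substituent on the pendant phenyl. In a functional assay on MCF7 cells (Homo sapiens) for cytotoxicity, read by MTT assay, with a stated time of 4 days (on this read-out higher numbers stand for weaker inhibition and lower numbers for stronger inhibition), compound 1 is reported only as a limit of the assay, > 20000 nM. In this assay compound 2 is likewise reported only as a limit, > 20000 nM. Among the compounds with values here, the one step joining them, a step that the two limits leave unreadable from compound 1 to compound 2, cannot be sized since (the limit of > 20000 nM in this assay, at which 3 of the 3 values shown sit). Compound 3 `C=C1C[C@]23C[C@@]1(O)CC[C@H]2c1cc(Br)c(O)c(C)c1[C@@H]3Cn1cc(-c2ccc(C)cc2)nn1`, which carries a free hydroxy on the core, in this assay also gives only a limit, > 20000 nM.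

Compound 4 `C=C1C[C@]23C[C@@]1(O)CC[C@H]2c1ccc(O)c(C)c1[C@@H]3Cn1cc(-c2ccc(OC)cc2)nn1` is not yet measured; relative to compound 2 the change is hydrogen in place of (4-methylphenyl)sulfonyl on an oxygen on an aromatic ring. Within the data shown here, no measured step bears directly on this change, and the sole measured step is unreadable. Compound 3 shows that a free hydroxy on the core with a substituted phenyl also sits at the limit. The expected step is therefore a step that the limit leaves unreadable from compound 2 to compound 4, nothing beyond the scatter in this assay. Compound 4 is expected at 30000 nM, within 8000 nM to 100000 nM, most likely again reported only as a limit.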

Compound 4, half-maximal inhibitory concentration: > 20000 nM
Compound 4 was reported as a limit (the forecaster's own chance of this, stated with the estimate: 80%); the middle value lies beyond the limit too.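

Compound 2 and compound 4 are both reported only as a limit in this assay, so the change from ((4-methylphenyl)sulfonyl)oxy to hydroxy gives no readable step: the limit of > 20000 nM in this assay, at which 4 of the 4 values shown sit.

The compounds shown leave open whether any change on the shared core or the pendant phenyl moves a compound off this limit.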